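The compounds below may be only part of what the source reports. "The series", "measured", "known", "first", "only" and "open" are said of these compounds alone.

Going by the values given here, compound 3 `C/C(=C\C(=O)Nc1ccccc1OCCCC(=O)O)c1ccc2c(ccn2Cc2ccc(C(F)(F)F)cc2)c1` gives the highest number of the three compounds measured so far in an assay on Prostate gland for inhibition of steroid 5-alpha-reductase (Rattus norvegicus) (a lower number here means a stronger inhibitor, a higher number a weaker inhibitor), namely 300 nM. Compound 1 `CCCC(C)n1ccc2cc(/C(C)=C/C(=O)Nc3ccccc3OCCCC(=O)O)ccc21` gives 7.8 nM and compound 2 `C/C(=C\C(=O)Nc1ccccc1OCCCC(=O)O)c1ccc2c(ccn2Cc2ccccc2C)c1` gives 69 nM in this assay. All steps among them turn on the group carried by the aromatic nitrogen: an 8.8-fold higher number from compound 1 to compound 2 (0.95 log units; beyond the scatter), a 38-fold higher number from compound 1 to compound 3 (1.59 log units; beyond the scatter) and a 4.3-fold higher number from compound 2 to compound 3 (0.64 log units; beyond the scatter).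

Compound 4 `CCCC(c1ccccc1)n1ccc2cc(/C(C)=C/C(=O)Nc3ccccc3OCCCC(=O)O)ccc21` is obtained from compound 3 by the change (1-phenylbutyl in place of 4-(trifluoromethyl)benzyl on an aromatic nitrogen). Among the compounds with values here, the 1-phenylbutyl group shares a branched saturated chain on the aromatic nitrogen with the 1-methylbutyl group of compound 1, which gave the lowest number so far, while the trifluoromethyl-bearing benzyl group leaves. The step most relevant here is a 38-fold higher number from compound 1 to compound 3 (1.59 log units; beyond the scatter), which describes the move from the branched chain to that benzyl group; compound 4 takes the reverse direction, with a phenyl kept on the chain. In this assay the expected step is a 15-fold lower number from compound 3 to compound 4 (1.18 log units; beyond the scatter), a clear decrease, though compound 1 need not be reached. The estimate for compound 4 in this assay is 20 nM, with a range from 5 nM to 80 nM.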

Compound 4, half-maximal inhibitory concentration: 9.1 nM
The estimate for compound 4 lay 2.2-fold (0.34 log units) above the measured number; low and high end bracket the measured number.
By their numbers in this assay, from the lowest: compounds 1 and 4 (each within the scatter of the next); then compound 2; then compound 3.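

In this assay the saturated chain carbon bound to the aromatic nitrogen accepts phenyl in place of methyl with no change that can be read: a 1.2-fold higher number from compound 1 to compound 4 (0.07 log units; within the scatter), which lies within the scatter. An aromatic ring in the group on this nitrogen therefore does not by itself go with a higher number, since 1-phenylbutyl, 2-methylbenzyl and 4-(trifluoromethyl)benzyl each hold one six-membered aromatic ring of carbon only, yet the new steps are a 33-fold lower number from compound 3 to compound 4 (1.52 log units; beyond the scatter) and a 7.6-fold lower number from compound 2 to compound 4 (0.88 log units; beyond the scatter), both beyond the scatter. Across the four compounds, the two groups with a branched chain give the two low numbers and the two benzyl groups give the higher ones, with no compound going against this split, although the benzyl groups also differ from the branched groups in more than the branch.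

No measurement at hand gives a reason for these steps. The compounds shown leave open whether the chain of 1-phenylbutyl can be shortened to ethyl or lengthened to hexyl with the number held, and whether a carboxylic acid or an amine on the phenyl ring of that group is accepted.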